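The source may hold more compounds than are shown below. What is called first, only, known or untested is meant among the compounds shown, and "the series" means these compounds.

Compound 1 `CC1=CCC[C@H]2[C@](C)(CC3=CC(=O)C=C(NCCC(=O)O)C3=O)[C@@H](C)CC[C@]12C` carries the shared core on a long hydrophobic tail, and in a functional assay on A549 cells (Homo sapiens) for cytotoxicity, read by MTT assay, with a stated time of 72 h (on this read-out lower numbers stand for stronger inhibition and higher numbers for weaker inhibition), compound 1 gives 26900 nM. Compound 3 `CC(C)[C@@H](NC1=CC(=O)C=C(C(C)(C)C)C1=O)C(=O)O` places the core on a short branched amino-acid chain, and in this assay compound 3 gives 154000 nM. Compound 2 `C[C@H](NC1=CC(=O)C=C(C(C)(C)C)C1=O)C(=O)O` returns no number in this assay, only a limit, > 200000 nM. Compound 2 therefore stands at the limit of > 200000 nM in this assay, at which 1 of the 3 values shown sits, the upper edge of what was measured. Compound 4 `CC(C)C[C@H](NC1=CC(=O)C=C(C(C)(C)C)C1=O)C(=O)O` has not yet been measured in this assay. It differs from compound 2 by isopropyl in place of hydrogen on a saturated chain carbon, two bonds along the chain from an amine nitrogen and a carbonyl carbon. Among the compounds with values here, no measured pair isolates exactly this change. Compound 3, whose chain is also branched and which does give a number, offers the nearest comparison. The step from compound 2 to compound 4 is expected to be modest, toward stronger inhibition if any, and is estimated as an at least 1.3-fold lower number from compound 2 to compound 4 (0.12 log units; that floor lies within the scatter). Compound 4 is expected to give about 150000 nM in this assay, with a plausible range from 60000 nM to 300000 nM.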

Compound 4, half-maximal inhibitory concentration: 97900 nM
The estimate for compound 4 lay 1.5-fold (0.19 log units) above the measured number; the range from low to high includes it.
By their numbers in this assay, from the lowest: compound 1; then compounds 4 and 3 (each within the scatter of the next). At a limit, above all of these: compound 2.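

In this assay, within the data shown here, isopropyl in place of hydrogen on a saturated chain carbon, two bonds along the chain from an amine nitrogen and a carbonyl carbon, gives an at least 2.0-fold lower number from compound 2 to compound 4 (0.31 log units; beyond the scatter), the first step at this position and one that lies beyond the scatter. Going by these compounds, compound 2 stands only at a limit, so this step is a floor and its full size stays unknown: the limit of > 200000 nM in this assay, at which 1 of the 4 values shown sits.

Compound 3 gives 154000 nM and compound 4 gives 97900 nM, values within the scatter of each other, so these two side chains cannot be told apart here.

The compounds shown leave open whether a phenyl group, a hydroxyl or an amine on this carbon would read the same way. They also leave open whether a longer chain here would shift the number further.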